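Returning the Ester Tail to a Smaller Group

The source may hold more compounds than are shown below. What is called first, only, known or untested is meant among the compounds shown, and "the series" means these compounds.

Compound 2, `CCCc1nc(CC)c(C(=O)OCCN2C(=O)c3ccccc3C2=O)n1Cc1ccc(-c2ccccc2S(=O)(=O)NC(=O)OCCC(C)C)cc1F`, gives the highest of the two numbers recorded so far in an assay on isolated protein for binding affinity to Type-2 angiotensin II receptor (Homo sapiens) (a lower number here means a stronger inhibitor, a higher number a weaker inhibitor), with a reading of 7 nM. Its nearest neighbour is compound 1, `CCCc1nc(CC)c(C(=O)OCCCOCc2ccccc2)n1Cc1ccc(-c2ccccc2S(=O)(=O)NC(=O)OCCC(C)C)cc1F`, which in this assay gives 2 nM; the step of a 3.5-fold higher number from compound 1 to compound 2 (0.54 log units; beyond the scatter) shows that replacing the smaller group with the larger one carrying the five-membered ring raised the number. Compound 3, `CCCc1nc(CC)c(C(=O)OCCC[S+]([O-])c2ccccc2)n1Cc1ccc(-c2ccccc2S(=O)(=O)NC(=O)OCCC(C)C)cc1F`, is not yet measured. It differs from compound 2 by a group of 9 heavy atoms (7 carbon, 1 oxygen, 1 sulfur; one six-membered aromatic ring of carbon only) in place of a group of 11 heavy atoms (8 carbon, 1 nitrogen, 2 oxygen; one five-membered non-aromatic ring with 1 hetero atom, one six-membered aromatic ring of carbon only), on a saturated chain carbon, two bonds along the chain from an oxygen next to a carbonyl group. Among the measured compounds shown here, the only measured step that bears on this exchange is the one from compound 1 to compound 2, which was modest, and the incoming group is again of the smaller size seen in compound 1. A modest fall in the number is therefore expected, a 2.3-fold lower number from compound 2 to compound 3 (0.37 log units; beyond the scatter). For compound 3 the estimate in this assay is 3 nM, within a range from 1 nM to 10 nM.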

Compound 3, half-maximal inhibitory concentration: 1 nM
For compound 3 the middle estimate is 3.0-fold (0.48 log units) above the measured one; the measured number falls inside the stated range.
By their numbers in this assay, from the lowest: compounds 3 and 1 (each within the scatter of the next); then compound 2.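

In this assay, exchanging the group with the five-membered non-aromatic ring for the sulfur-containing group gives a 7.0-fold lower number from compound 2 to compound 3 (0.85 log units; beyond the scatter), so a second group without that ring also reads lower than compound 2 at this saturated chain carbon. The two groups without that ring cannot be ranked, since the comparison between them reads a 2.0-fold lower number from compound 1 to compound 3 (0.30 log units; within the scatter), even though one carries sulfur and the other does not. Nothing measured here explains these differences in binding.

Among the compounds shown here, with only three compounds, it stays open whether the higher number of compound 2 goes with the five-membered ring itself or with the larger group as a whole. An amine or a carboxylic acid on the same saturated chain carbon would show whether the six-membered aromatic ring, shared by all three groups, is needed at all.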